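Chloro for Trifluoromethyl on a Triazole-Linked Phenyl Ring

The compounds below may be only part of what the source reports. "The series", "measured", "known", "first", "only" and "open" are said of these compounds alone.

The three measured compounds:
- compound 1 `Cc1c(O)ccc2c1[C@H](Cn1cc(-c3ccccc3)nn1)[C@@]13CC(=O)[C@@](C)(CC[C@@H]21)C3` gives > 20000 nM in a functional assay on A549 cells (Homo sapiens) for cytotoxicity, read by MTT assay, with a stated time of 4 days (a higher number here means a weaker inhibitor, a lower number a stronger inhibitor), which is a limit of the assay and not a number.
- compound 2 `C=C1C(=O)[C@]23C[C@@]1(O)CC[C@H]2c1ccc(O)c(C)c1[C@@H]3Cn1cc(-c2ccc(C(F)(F)F)cc2)nn1` gives 1110 nM in this assay.
- compound 3 `C=C1C[C@]23C[C@@]1(O)CC[C@H]2c1ccc(O)c(C)c1[C@@H]3Cn1cc(-c2ccccc2)nn1` gives > 20000 nM in this assay, again a limit and not a number.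

Among the compounds with values here, compound 2 therefore holds the only number among the three values shown; the other two sit at the limit of > 20000 nM in this assay, at which 2 of the 3 values shown sit. Within the data shown here, no pair of measured compounds differs in just one place, so no measured step is available to guide the next comparison.

Compound 4 `C=C1C(=O)[C@]23C[C@@]1(O)CC[C@H]2c1ccc(O)c(C)c1[C@@H]3Cn1cc(-c2ccc(Cl)cc2)nn1` differs from compound 2 in one place: chloro in place of trifluoromethyl on an aromatic carbon. Among the measured compounds shown here, since no measured step of this kind exists, the expectation rests on compound 2 alone. A step of a 1.8-fold higher number from compound 2 to compound 4 (0.26 log units; within the scatter) from compound 2 to compound 4 is expected, a modest shift towards a weaker inhibitor that may well stay within the usual scatter. Compound 4 is expected to give about 2000 nM in this assay, with a range from 700 nM to 8000 nM.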

Compound 4, half-maximal inhibitory concentration: 640 nM
For compound 4 the middle estimate is 3.1-fold (0.49 log units) above the measured one; measured number below the stated range.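

In this assay, the change from 4-(trifluoromethyl)phenyl to 4-chlorophenyl gives a 1.7-fold lower number from compound 2 to compound 4 (0.24 log units; within the scatter), so this read-out does not separate the two compounds. At this aromatic carbon, para to a large group, a single chlorine atom therefore does as well as the four heavy atoms of trifluoromethyl, and the activity of compound 2 is not tied to that one group. Compound 4 also gives a number and not a limit, so compound 2 no longer stands alone in this respect: the limit of > 20000 nM in this assay, at which 2 of the 4 values shown sit.

Compound 1 and compound 3 carry a phenyl ring without this group but differ from compound 4 in other places too, so they cannot show what the group itself contributes. Going by these compounds, whether an amine or a carboxylic acid at this position would keep a measurable number remains open.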